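A chlorine change from compound 2 to compound 3

The source may report more compounds than this note shows. Statements on the series, on what has been measured and on what is new or still open speak of the compounds shown alone.

Compound 1 `Cc1cccc(-n2cc(-c3ccc(/C=C4\C(=O)Nc5ccc(F)cc54)cc3)nn2)c1` gives 6810 nM
Compound 2 `O=C1Nc2ccc(F)cc2/C1=C/c1ccc(-c2cn(-c3ccccc3Cl)nn2)cc1` gives 7540 nM

Going by the values given here, in a functional assay on MKN-45 cells (Homo sapiens) for inhibition, read by CCK-8 assay, with a stated time of 24 h (on this read-out higher numbers stand for weaker inhibition and lower numbers for stronger inhibition), compound 2 stands level with compound 1, its only measured neighbour. Compound 3 `O=C1Nc2ccc(F)cc2/C1=C/c1ccc(-c2cn(-c3cccc(Cl)c3)nn2)cc1` has 3-chlorophenyl in place of 2-chlorophenyl on an aromatic nitrogen. Among the compounds with values here, no measured step makes this exact exchange. The nearest evidence is the exchange of 3-methylphenyl for 2-chlorophenyl, which gave a 1.1-fold higher number from compound 1 to compound 2 (0.04 log units; within the scatter) and so offers no sign of a large change. No shift beyond the scatter is therefore expected, and the estimated change is a 1.1-fold lower number from compound 2 to compound 3 (0.03 log units; within the scatter) in this assay. Compound 3 is estimated at 7000 nM, with an expected range from 3000 nM to 15000 nM.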

Compound 3, half-maximal inhibitory concentration: 14100 nM
For compound 3 the middle estimate is 2.0-fold (0.30 log units) below the measured one, and the stated range covers the measured number.
By their numbers in this assay, from the lowest: compounds 1, 2 and 3 (each within the scatter of the next, the first and the last beyond it).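

In this assay, moving the chlorine gives a 1.9-fold higher number from compound 2 to compound 3 (0.27 log units; within the scatter), so the position of this chlorine on the phenyl group has not yet been shown to matter. Chloro in place of methyl on an aromatic carbon gives a 2.1-fold higher number from compound 1 to compound 3 (0.32 log units; beyond the scatter), the first step at this group to pass beyond the scatter, though only modestly. Nothing available bears on the reason for that step. The compounds shown leave open how an amine or a carboxylic acid on this phenyl group would read, and whether any change here could give a much lower number.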